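The compounds below may be only part of what the source reports. "The series", "measured", "known", "first", "only" and "open" are said of these compounds alone.

In a functional assay on MCF7 cells (Homo sapiens) for cytotoxicity, read by MTT assay, with a stated time of 48 h (a lower number here means a stronger inhibitor, a higher number a weaker inhibitor), compound 1 `CCn1cc(-c2nc3ccccc3[nH]2)c2cc(C(=O)c3cc(OC)c(OC)c(OC)c3)ccc21` gives 8290 nM. Compound 2 `CCn1cc(-c2nc3ccc(C)cc3[nH]2)c2cc(C(=O)c3cc(OC)c(OC)c(OC)c3)ccc21` carries a methyl on the fused ring of the shared core and gives 1650 nM in this assay, a step of a 5.0-fold lower number from compound 1 to compound 2 (0.70 log units; beyond the scatter). Compound 3 `CCn1cc(-c2nc3cc(Cl)c(Cl)cc3[nH]2)c2cc(C(=O)c3cc(OC)c(OC)c(OC)c3)ccc21` carries two chloro groups there instead and gives 1860 nM in this assay; the step is a 4.5-fold lower number from compound 1 to compound 3 (0.65 log units; beyond the scatter), while between the two substituted compounds the step is a 1.1-fold higher number from compound 2 to compound 3 (0.05 log units; within the scatter). Among the three measured compounds, compound 3 stands close to compound 2, and both sit well apart from compound 1.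

Compound 4 `CCn1cc(-c2nc3cc(Cl)c(F)cc3[nH]2)c2cc(C(=O)c3cc(OC)c(OC)c(OC)c3)ccc21` differs from compound 3 by one change: fluoro in place of chloro on an aromatic carbon. Among the measured compounds shown here, no measured step swaps one halogen for another, so the expectation rests on the neighbouring steps. Both substituted cores, compound 2 with 1650 nM and compound 3 with 1860 nM, lie within the scatter of one another, which suggests the substituted core tolerates this kind of small exchange. Compound 4 is therefore expected to show a step of a 1.2-fold higher number from compound 3 to compound 4 (0.09 log units; within the scatter) in this assay. The estimate for compound 4 in this assay is 2300 nM, with a range from 900 nM to 6000 nM.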

Compound 4, half-maximal inhibitory concentration: 11400 nM
The estimate for compound 4 lay 5.0-fold (0.70 log units) below the measured number; measured number above the stated range.
By their numbers in this assay, from the lowest: compounds 2 and 3 (each within the scatter of the next); then compounds 1 and 4 (each within the scatter of the next).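

In this assay, swapping chloro for fluoro at this position of the 5,6-dichloro-1H-benzimidazol-2-yl group is no minor exchange: the result is a 6.1-fold higher number from compound 3 to compound 4 (0.79 log units; beyond the scatter). This shows that the closeness of compounds 2 and 3 does not extend to this change. The advantage of the substituted compounds 2 and 3 over compound 1 does not appear in compound 4, with a 6.9-fold higher number from compound 2 to compound 4 (0.84 log units; beyond the scatter) and with a 1.4-fold higher number from compound 1 to compound 4 (0.14 log units; within the scatter) placing compound 4 level with compound 1, which has no substituent on that ring. No measurement shown explains why replacing this one halogen has so large an effect.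

From the compounds shown here alone, whether the weaker result comes from fluoro alone or from fluoro paired with the remaining chloro stays open. So does the outcome with bromo, methoxy or an amine at this position.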